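Iodo to fluoro on two cores and cytotoxicity

The source may hold more compounds than are shown below. What is called first, only, known or untested is meant among the compounds shown, and "the series" means these compounds.

Compound 1 `O=c1oc2ccc(Br)cc2c(=O)n1-c1ccc(I)cc1F` and compound 3 `O=c1oc2ccc(Br)cc2c(=O)n1-c1ccc(F)cc1F` share one core, while compound 2 `O=C(Nc1ccc(Br)cc1F)c1cc(I)ccc1O` is built on another; the difference between the two cores is not broken down here. In an ADME assay on RAW264.7 cells (Mus musculus) for cytotoxicity, read by MTT assay, with a stated time of 24 h (on this read-out lower numbers stand for higher toxicity in this test and higher numbers for lower toxicity in this test), compound 1 gives 7900 nM, compound 3 gives 16000 nM and compound 2 gives 8400 nM. The change from compound 1 to compound 3, (fluoro in place of iodo on an aromatic carbon), produced a 2.0-fold higher number from compound 1 to compound 3 (0.31 log units; beyond the scatter). Compound 4 `O=C(Nc1ccc(Br)cc1F)c1cc(F)ccc1O` differs from compound 2 by fluoro in place of iodo on an aromatic carbon, the same kind of change, though here the carbon is meta to a large group and para to a hydroxy group, whereas in compound 3 it is meta to a fluoro group and para to a large group. In this assay a step of a 1.8-fold higher number from compound 2 to compound 4 (0.25 log units; within the scatter) is expected because the same kind of change gave a 2.0-fold higher number from compound 1 to compound 3 (0.31 log units; beyond the scatter). Compound 4 is therefore estimated at 15000 nM, between 7000 nM and 32000 nM.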

Compound 4, half-maximal cytotoxic concentration: 7900 nM
For compound 4 the middle estimate is 1.9-fold (0.28 log units) above the measured one; low and high end bracket the measured number.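

In this assay, fluoro in place of iodo on the second core gives a 1.1-fold lower number from compound 2 to compound 4 (0.03 log units; within the scatter), so the step stays within the scatter, whereas on the first core it lies just beyond it. Set side by side, the two steps cannot be told apart: the same change on two cores in this assay, a 2.0-fold higher number (0.31 log units; beyond the scatter) from compound 1 to compound 3 and a 1.1-fold lower number (0.03 log units; within the scatter) from compound 2 to compound 4, 2.2-fold (0.33 log units) apart, within the scatter of two such steps. This shows no measurable dependence on the core, but it does not show that the change carries over with the same size, and one step on each core cannot settle whether the cores truly differ. The compounds shown leave open how chloro, methoxy or an amine on that carbon would behave on either core. They also leave open whether any such group would separate the two cores more clearly.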